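From isopropyl to methyl on compound 2

The source may hold more compounds than are shown below. What is called first, only, known or untested is meant among the compounds shown, and "the series" means these compounds.

In a physicochemical assay for solubility, measured as thermodynamic solubility (on this read-out higher numbers stand for higher solubility and lower numbers for lower solubility), compound 1 `Nc1ncc(-c2ccc(C(=O)N3CC(O)C3)cc2)nc1-c1ccc(C(F)(F)F)nc1` gives 55000 nM and compound 2 `CC(C)c1nc(N2CCN(c3ncc(OCc4ccncc4C#N)cn3)CC2)no1` gives 6000 nM as the lower of the two numbers, a gap beyond the usual scatter. These two compounds differ in many places, so their gap cannot be tied to any single group.

Compound 3 `Cc1nc(N2CCN(c3ncc(OCc4ccncc4C#N)cn3)CC2)no1` differs from compound 2 in one place only, with methyl in place of isopropyl on an aromatic carbon as the counted change. This is methyl in place of isopropyl on an aromatic carbon, or 5-isopropyl-1,2,4-oxadiazol-3-yl to 5-methyl-1,2,4-oxadiazol-3-yl, and the rest of the molecule stays the same.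

Within the data shown here, no measured pair shows this change, so the forecast is a judgement. A moderate rise is expected, only a little beyond the scatter, and the expected step is a 2.5-fold higher number from compound 2 to compound 3 (0.40 log units; beyond the scatter) in this assay as a rough estimate. The expected value for compound 3 is 15000 nM within an estimated range from 5000 nM to 40000 nM for repeat measurements.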

Compound 3, solubility: 64000 nM
Compound 3: middle estimate off by 4.3-fold (0.63 log units), on the low side, outside the stated range (above it).
By their numbers in this assay, from the lowest: compound 2; then compounds 1 and 3 (each within the scatter of the next).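

In this assay, 5-isopropyl-1,2,4-oxadiazol-3-yl to 5-methyl-1,2,4-oxadiazol-3-yl gives an 11-fold higher number from compound 2 to compound 3 (1.03 log units; beyond the scatter), a large step that goes well beyond the usual scatter. The first two compounds differ in many places, so their gap could not be tied to any one group, whereas this pair shows that a change at a single place, on an aromatic carbon of the five-membered ring, can by itself move this read-out by a large amount. Nothing measured here gives a cause for the step.

On these data alone, with only isopropyl and methyl compared at this carbon, it remains open whether an ethyl group, a cyclopropyl group or an amine would give a number closer to that of compound 2 or compound 3. One pair also cannot show whether the same swap would have a similar effect on a different core.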